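Lengthening the chain to the 4-chlorophenoxy group

This account rests on a few compounds, and the source may have more. Where it says the series, first, only, none or still open, it means among the compounds named here.

Compound 1 `Cc1cc(C)c(NC(=O)C(C)(C)CCCCCCN2CCCCC2)c2c1CC(C)(C)O2`; compound 2 `Cc1cc(C)c(NC(=O)C(C)(C)CCCCCCc2ccccc2)c2c1CC(C)(C)O2`; compound 3 `Cc1cc(C)c(NC(=O)C(C)(C)CCCOc2ccc(Cl)cc2)c2c1CC(C)(C)O2`.

In an assay for inhibition of acyl-CoA:cholesterol acyltransferase (Oryctolagus cuniculus), using microsomes (on this read-out higher numbers stand for weaker inhibition and lower numbers for stronger inhibition), compound 2 gives 81 nM and compound 3 gives 260 nM. For compound 1 the assay reports only a limit, > 500 nM (the limit of > 500 nM in this assay, at which 1 of the 3 values shown sits). Among the numbers shown, compound 3 stands highest; its nearest neighbour is compound 2, with a 3.2-fold higher number from compound 2 to compound 3 (0.51 log units; beyond the scatter).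

Compound 4 `Cc1cc(C)c(NC(=O)C(C)(C)CCCCCCOc2ccc(Cl)cc2)c2c1CC(C)(C)O2` differs from compound 3 by 3-(4-chlorophenoxy)propyl in place of 4-chlorophenoxy on a saturated chain carbon, four bonds along the chain from a carbonyl carbon. The measured steps that bear on this change are an at least 6.1-fold lower number from compound 1 to compound 2 (0.79 log units; beyond the scatter), an at least 1.9-fold lower number from compound 1 to compound 3 (0.28 log units; that floor lies within the scatter) and a 3.2-fold higher number from compound 2 to compound 3 (0.51 log units; beyond the scatter). Compound 2, which carries its phenyl seven bonds along the chain from the carbonyl carbon, gives the lower number, while compound 3, whose 4-chlorophenoxy sits four bonds along, gives the higher one. Compound 4 places the 4-chlorophenoxy group at the end of a longer chain, as compound 2 places its phenyl, so a lower number is expected in this assay, with a 2.4-fold lower number from compound 3 to compound 4 (0.37 log units; beyond the scatter). Compound 4 is estimated at 110 nM, within a range from 40 nM to 300 nM.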

Compound 4, half-maximal inhibitory concentration: 76 nM
Estimate against measurement, compound 4: 1.4-fold (0.16 log units) above; the range from low to high includes it.
By their numbers in this assay, from the lowest: compounds 4 and 2 (each within the scatter of the next); then compound 3. At a limit, above all of these: compound 1.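

In this assay, 3-(4-chlorophenoxy)propyl in place of 4-chlorophenoxy on a saturated chain carbon, four bonds along the chain from a carbonyl carbon, gives a 3.4-fold lower number from compound 3 to compound 4 (0.53 log units; beyond the scatter); with the 4-chlorophenoxy end held fixed, this isolates the effect of chain length, which the earlier comparison of compound 2 with compound 3 could not separate from the change of end group. At the longer chain, the two aromatic ends cannot be told apart, with a 1.1-fold lower number from compound 2 to compound 4 (0.03 log units; within the scatter). The piperidin-1-yl end stands apart from both, with an at least 6.5-fold lower number from compound 1 to compound 4 (0.81 log units; beyond the scatter), and the size of that step is only a floor, as compound 1 is known through a limit: the limit of > 500 nM in this assay, at which 1 of the 4 values shown sits.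

As far as these compounds go, what a longer chain still would do with the 4-chlorophenoxy end stays open, as does whether the trend between compound 3 and compound 4 would continue or reverse. From the compounds shown here alone, it is also open whether a carboxylic acid or a morpholine at the chain end would give numbers like those of the aromatic ends or would behave as the piperidin-1-yl group does.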